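A few compounds are considered here, and "the series" means these few. Any claim that something is new, unique, unknown or untested is made for them only; others in the source may bear on it.

Measured in a functional assay for inhibition, with Homo sapiens as the target; on this read-out lower numbers stand for stronger inhibition and higher numbers for weaker inhibition:
- compound 1 `CC(C)(C)Sc1c(CC(C)(C)C(=O)O)n(Cc2ccc(Cl)cc2)c2ccc(OCc3ccc4cc(F)c(F)cc4n3)cc12`: 7 nM
- compound 2 `CC(C)(C)Sc1c(CC(C)(C)C(=O)O)n(Cc2ccc(Cl)cc2)c2ccc(OCc3cc4ccccc4cn3)cc12`: 3 nM
- compound 3 `CC(C)(C)Sc1c(CC(C)(C)C(=O)O)n(Cc2ccc(Cl)cc2)c2ccc(OCc3ccc4cccnc4n3)cc12`: 6 nM

Compound 3 sits at 6 nM, level with the other two within the usual scatter. The steps to it are a 1.2-fold lower number from compound 1 to compound 3 (0.07 log units; within the scatter) and a 2.0-fold higher number from compound 2 to compound 3 (0.30 log units; within the scatter).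

Compound 4 `CC(C)(C)Sc1c(CC(C)(C)C(=O)O)n(Cc2ccc(Cl)cc2)c2ccc(OCc3nc4ccccc4s3)cc12` makes one change: a group of 9 heavy atoms (7 carbon, 1 nitrogen, 1 sulfur; one five-membered aromatic ring with 2 hetero atoms, one six-membered aromatic ring of carbon only) in place of a group of 10 heavy atoms (8 carbon, 2 nitrogen; 2 six-membered aromatic rings with 1 hetero atom each), on a saturated chain carbon bound to an oxygen on an aromatic ring. The three measured swaps at this same place were all small. The largest, and the only one beyond the scatter, was a 2.3-fold lower number from compound 1 to compound 2 (0.37 log units; beyond the scatter). None of them brought in a five-membered aromatic ring or sulfur, so the precedent is only indirect. No step beyond the scatter is therefore expected in this assay. The estimated step is a 1.2-fold lower number from compound 3 to compound 4 (0.08 log units; within the scatter). For compound 4 the expected value is 5 nM, with an estimated range from 2 nM to 15 nM.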

Compound 4, half-maximal inhibitory concentration: 3 nM
The estimate for compound 4 lay 1.7-fold (0.22 log units) above the measured number; the measured number falls inside the stated range.
By their numbers in this assay, from the lowest: compounds 2, 4, 3 and 1 (each within the scatter of the next, the first and the last beyond it).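

Placing 1,3-benzothiazol-2-yl at this position shows that a five-membered aromatic ring with sulfur keeps the number in the same range in this assay with a 2.0-fold lower number from compound 3 to compound 4 (0.30 log units; within the scatter) and with no change at the digits printed from compound 2 to compound 4 (within the scatter). Among the compounds shown here, only one comparison passes the scatter, and modestly, with a 2.3-fold lower number from compound 1 to compound 4 (0.37 log units; beyond the scatter). No measurement here offers an explanation for these differences. Still open, on these data alone, is whether a single ring, such as pyridine or thiophene, would serve as well as these two-ring groups. Also open, as far as these compounds go, is what an amine on the 1,3-benzothiazol-2-yl group would do.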